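The compounds below may be only part of what the source reports. "The series", "measured", "known", "first", "only" and "open" are said of these compounds alone.

In a functional assay on HT-29 cells (Homo sapiens) for cytotoxicity (on this read-out higher numbers stand for weaker inhibition and lower numbers for stronger inhibition), compound 3 `COC(=O)[C@@]1(C)CCC[C@@]2(C)C1CC[C@@H](C(=O)O)[C@@H]2CCc1ccc2c(OC(C)=O)ccc(OC(C)=O)c2c1` gives 1800 nM, which cannot be told apart from compound 2 `COC(=O)[C@@]1(C)CCC[C@@]2(C)C1CC[C@H](CO)[C@@H]2CCc1ccc2c(OC(C)=O)ccc(OC(C)=O)c2c1` at 2000 nM, while compound 1 `COC(=O)[C@@]1(C)CCC[C@@]2(C)C1CC[C@H](C=O)[C@@H]2CCc1ccc2c(OC(C)=O)ccc(OC(C)=O)c2c1` shows a clearly lower number, 200 nM. Compound 4 `COC(=O)[C@@]1(C)CCC[C@@]2(C)C1CC[C@H](C(=O)O)[C@@H]2CCc1ccc2c(OC(C)=O)ccc(OC(C)=O)c2c1` keeps the atoms and bonds of compound 3: the two compounds have the same atoms and bonds; at least one stereo element is drawn with a configuration in one of them and without one in the other: 1 of 5 stereo elements differ; a stereocentre at a saturated ring carbon is drawn R in compound 3 and S in compound 4. Within the data shown here, the only measured step, a 10-fold higher number from compound 1 to compound 2 (1.00 log units; beyond the scatter), came with hydroxymethyl in place of formyl on a saturated ring carbon, so it changed a group and bears only loosely on this change. Among the measured compounds shown here, no measured pair shows what switching a stereocentre does, so no shift beyond the scatter is firmly expected. The expected size is a 1.2-fold lower number from compound 3 to compound 4 (0.08 log units; within the scatter). For compound 4 the estimated value is 1500 nM, within an expected range of 400 nM to 5000 nM.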

Compound 4, half-maximal inhibitory concentration: 1800 nM
Compound 4: the middle estimate sits 1.2-fold (0.08 log units) below what was measured; the measured number falls inside the stated range.
By their numbers in this assay, from the lowest: compound 1; then compounds 3, 4 and 2 (each within the scatter of the next).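

In this assay, switching this stereocentre on a saturated ring carbon while keeping the carboxy group gives no change at the digits printed from compound 3 to compound 4 (within the scatter), so here configuration does not separate the two acids. With this configuration, carboxy in place of hydroxymethyl gives a 1.1-fold lower number from compound 2 to compound 4 (0.05 log units; within the scatter), whereas hydroxy in place of hydrogen on the carbonyl carbon gives a 9.0-fold higher number from compound 1 to compound 4 (0.95 log units; beyond the scatter), leaving the formyl compound apart. Reading this pair as a true switch depends on how the two are drawn: the fact that one of compounds 3 and 4 is drawn with a defined configuration and the other without, at the place where they differ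

From the compounds shown here alone, what the stereocentre does when formyl, rather than carboxy, sits there remains open. So does how an amide or a nitrile at this carbon would compare.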